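A few compounds are considered here, and "the series" means these few. Any claim that something is new, unique, unknown or untested is made for them only; others in the source may bear on it.

Working notes on the series in an ADME assay on Huh-7 cells (Homo sapiens) for cytotoxicity; a lower number here means that less compound is tolerated, a higher number that more compound is tolerated. Compound 1 `Cc1csc2nc(C(=O)N3CCN(C4CCCC4)C(=O)C3)c(Cl)n12` gives > 10000 nM, which is a limit of the assay and not a number. Compound 2 `O=C(c1nc2scc(C3CC3)n2c1Cl)N1CCN(C2CCCC2)C(=O)C1` gives > 10000 nM, again only a limit, so its standing carries no readable number. Compound 3 `CC(C)Cc1csc2nc(C(=O)N3CCN(C4CCCC4)C(=O)C3)c(Cl)n12` keeps the core of compound 2 and takes isobutyl in place of cyclopropyl on an aromatic carbon. Among the compounds with values here, the one measured step bearing on this change is a step that the two limits leave unreadable from compound 1 to compound 2, and it has no readable size. For compound 1 and compound 2 the evidence is the limit of > 10000 nM in this assay, at which 2 of the 2 values shown sit, so no step beyond the scatter and no direction is expected in this assay. The expected step is a step that the limit leaves unreadable from compound 2 to compound 3. For compound 3 the estimated value is 15000 nM, with an expected range from 7000 nM to 30000 nM.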

Compound 3, half-maximal cytotoxic concentration: > 10000 nM
Compound 3 was reported as a limit; the forecaster's own chance of this, stated with the estimate: 90%; the middle value does not contradict the limit.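

In this assay, within the data shown here, compound 3 gives > 10000 nM as a limit and not a number, so no step among compound 1, compound 2 and compound 3 can be read: the limit of > 10000 nM in this assay, at which 3 of the 3 values shown sit. Still open, as far as these compounds go, is whether methyl, cyclopropyl and isobutyl differ at all in half-maximal cytotoxic concentration.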